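Swapping a sulfo group for a hydroxy on a side chain

The compounds below may be only part of what the source reports. "The series", "measured", "known", "first", "only" and "open" are said of these compounds alone.

Three compounds sharing the same kind of side chain were tested in a functional assay on HSC-2 cells (Homo sapiens) for cytotoxicity, read by MTT assay, with a stated time of 48 h; a higher number here means that more compound is tolerated, a lower number that less compound is tolerated. Compound 1 `O=C1/C(=C/c2ccc(Cl)cc2)CN(C(=O)CCSCCO)C/C1=C\c1ccc(Cl)cc1` gives 660 nM. Compound 2 `COc1ccc(/C=C2\CN(C(=O)CCSCCS(=O)(=O)O)C/C(=C\c3ccc(OC)cc3)C2=O)cc1` gives 91700 nM, the highest number of the three. Compound 3 `O=C1/C(=C/c2ccc(Cl)cc2)CN(C(=O)CCSCCS(=O)(=O)O)C/C1=C\c1ccc(Cl)cc1` gives 29700 nM. Compound 1 and compound 3 differ in one place: hydroxy in place of sulfo on a saturated chain carbon, two bonds along the chain from a sulfur. That change made a step of a 45-fold lower number from compound 3 to compound 1 (1.65 log units; beyond the scatter) in this assay. Compound 4 `COc1ccc(/C=C2\CN(C(=O)CCSCCO)C/C(=C\c3ccc(OC)cc3)C2=O)cc1` has not yet been measured; it differs from compound 2 in the same way, (hydroxy in place of sulfo on a saturated chain carbon, two bonds along the chain from a sulfur), at a place described in the same words. The two cores, that of compound 2 and that of compound 3, differ in more than one place, and the difference between them is not broken down here, so the change in compound 4 is the same kind of change as that from compound 3 to compound 1, made on a different core. Whether the step carries over to another core is not known from these data. Compound 4 is therefore expected to show a step of a 37-fold lower number from compound 2 to compound 4 (1.56 log units; beyond the scatter) in this assay, somewhat smaller than the step of a 45-fold lower number from compound 3 to compound 1 (1.65 log units; beyond the scatter). Compound 4 is estimated at 2500 nM, with a range from 800 nM to 8000 nM.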

Compound 4, half-maximal cytotoxic concentration: 2670 nM
Beside the measured number, compound 4's estimate is 1.1-fold (0.03 log units) below it, and the stated range covers the measured number.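

In this assay, putting hydroxy in place of sulfo on the second core gives a step of a 34-fold lower number from compound 2 to compound 4 (1.54 log units; beyond the scatter), so the large fall seen on the first core appears here too. The two steps match in size as closely as repeated measurements can show: the same change on two cores in this assay, a 45-fold lower number (1.65 log units; beyond the scatter) from compound 3 to compound 1 and a 34-fold lower number (1.54 log units; beyond the scatter) from compound 2 to compound 4, 1.3-fold (0.12 log units) apart, within the scatter of two such steps. Across these two cores, then, the change carried over with much the same size, but two pairs cannot show that it would do so on every other core in this series, and they do not say why the number falls.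

The compounds shown leave open what other groups would do at this place on the chain, such as an amine or a carboxylic acid, and whether a longer chain carrying the hydroxy would keep the lower number. They also leave open whether the same step would appear in cells other than these.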